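Replacing a Benzoyl Group with Isopropylcarbamoyl: an Estimate

A few compounds are considered here, and "the series" means these few. Any claim that something is new, unique, unknown or untested is made for them only; others in the source may bear on it.

Measured compounds:
compound 1 `Cc1ccc(C(=O)c2nc(NCc3ccccn3)nc3ccsc23)s1` — 43 nM
compound 2 `O=C(c1ccc(Cl)s1)c1nc(NCc2cccnc2)nc2ccsc12` — 487 nM
compound 3 `O=C(c1ccccc1)c1nc(NCc2cccnc2)nc2ccsc12` — 511 nM

In a functional assay on CHO-K1 cells for antagonist activity at adenosine receptor A2b (Homo sapiens), read by FLIPR and calcium flux (on this read-out lower numbers stand for stronger inhibition and higher numbers for weaker inhibition), compound 3 gives 511 nM, the highest of the three numbers. Its nearest neighbour is compound 2, and the step of a 1.0-fold higher number from compound 2 to compound 3 (0.02 log units; within the scatter) lies within the scatter. The furthest is compound 1, which gives 43 nM in this assay; that gap is beyond the scatter, though the two compounds differ at more than one place.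

Compound 4 `CC(C)NC(=O)c1nc(NCc2cccnc2)nc2ccsc12` differs from compound 3 by isopropylamino in place of phenyl on a carbonyl carbon. Among the compounds with values here, the only measured step at this carbonyl carbon, a 1.0-fold higher number from compound 2 to compound 3 (0.02 log units; within the scatter), swapped one aromatic ring for another and changed nothing beyond the scatter. Within the data shown here, no measured step replaces the aromatic ring with an amino group, so the present change is of a kind not yet seen in this set. Compound 4 is therefore expected to land near compound 3, with a wide range, and the expected step of a 1.6-fold higher number from compound 3 to compound 4 (0.19 log units; within the scatter) is small. The estimate for compound 4 in this assay is 800 nM, between 250 nM and 3000 nM.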

Compound 4, half-maximal inhibitory concentration: 309 nM
Estimate against measurement, compound 4: 2.6-fold (0.41 log units) above; low and high end bracket the measured number.
By their numbers in this assay, from the lowest: compound 1; then compounds 4, 2 and 3 (each within the scatter of the next).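

In this assay, the change from benzoyl to isopropylcarbamoyl gives a 1.7-fold lower number from compound 3 to compound 4 (0.22 log units; within the scatter) and so stays within the scatter. This shows that the carbonyl carbon need not carry an aromatic ring at all: isopropylamino, with no ring and with a hydrogen-bond donor that phenyl lacks, leaves the number where the two aromatic groups put it. The comparison with the other aromatic group reads the same, with a 1.6-fold lower number from compound 2 to compound 4 (0.20 log units; within the scatter) also within the scatter, and nothing available here explains why these different groups give such similar numbers.

The compounds shown leave open whether a longer chain, a cyclic amine such as morpholine or a bare primary amide would be tolerated on this carbonyl carbon. They also leave open whether the same swap would hold in the setting of compound 1, which gives 43 nM in this assay.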